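The compounds below may be only part of what the source reports. "The series", "measured", "known", "first", "only" and "open" are said of these compounds alone.

Measured so far in a functional assay on PC-3 cells (Homo sapiens) for cytotoxicity, read by sulforhodamine B assay, with a stated time of 48 h; on this read-out higher numbers stand for weaker inhibition and lower numbers for stronger inhibition:

- Compound 1 `COc1ccc(C2=NO[C@]3(C2)C(=O)O[C@@H]2[C@H]3CC[C@H](C)[C@]3(O)C=CC(=O)[C@@]23C)cc1OC`: 25000 nM
- Compound 2 `COc1cc(C2=NO[C@]3(C2)C(=O)O[C@@H]2[C@H]3CC[C@H](C)[C@]3(O)C=CC(=O)[C@@]23C)ccc1O`: 16000 nM

In this assay, within the data shown here, compound 2 gives 16000 nM, the lower of only two numbers, but its place in that order means little. The step to it is a 1.6-fold lower number from compound 1 to compound 2 (0.19 log units; within the scatter), and it consists of hydrogen in place of methyl on an oxygen on an aromatic ring.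

The next compound, compound 3 `C[C@H]1CC[C@@H]2[C@@H](OC(=O)[C@]23CC(c2ccccc2F)=NO3)[C@]2(C)C(=O)C=C[C@@]12O`, keeps the shared core and carries 2-fluorophenyl in place of 4-hydroxy-3-methoxyphenyl on a carbon with a double bond to nitrogen. This is a larger change than the measured one, since the hydroxy and methoxy groups both leave and a fluorine enters. Among the measured compounds shown here, only that single step bears on it, and it touches the same aromatic ring. For the measured compounds named here, no measured compound shows what fluorine does here, so the data give no direction. From compound 2, with its step of a 1.6-fold lower number from compound 1 to compound 2 (0.19 log units; within the scatter), no change beyond the scatter is expected in this assay.

The expected step is a 1.1-fold higher number from compound 2 to compound 3 (0.05 log units; within the scatter).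

For compound 3 the estimated value is 18000 nM, with an expected range from 6000 nM to 50000 nM.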

Compound 3, half-maximal inhibitory concentration: 8200 nM
Compound 3: the middle estimate sits 2.2-fold (0.34 log units) above what was measured; measured number inside the range.
By their numbers in this assay, from the lowest: compounds 3, 2 and 1 (each within the scatter of the next, the first and the last beyond it).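

In this assay, 2-fluorophenyl in place of 4-hydroxy-3-methoxyphenyl on the carbon with a double bond to nitrogen gives a 2.0-fold lower number from compound 2 to compound 3 (0.29 log units; within the scatter), so this change cannot be told apart from the scatter. Among these compounds, the same group in place of 3,4-dimethoxyphenyl gives a 3.0-fold lower number from compound 1 to compound 3 (0.48 log units; beyond the scatter), the first step in this short series to pass the scatter, though only a modest one. The position therefore accepts a phenyl ring with neither hydroxy nor methoxy on it without any loss in this read-out, and nothing measured here explains the step from compound 1 to compound 3.

Both steps to compound 3 remove the oxygen groups and bring in the fluorine at once, so the compounds shown cannot separate the effect of one from the other or tell whether the place of the fluorine on the ring matters. They also leave open how unsubstituted phenyl, or a ring carrying an amine or a carboxylic acid, would read at this position.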